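Five-membered heteroaryl swap on the biaryl of compound 2

This account rests on a few compounds, and the source may have more. Where it says the series, first, only, none or still open, it means among the compounds named here.

Compound 2 `C[C@@H](Nc1nccc(Cl)c1NC(=O)CC#N)c1ccc(-c2cccc(F)c2-c2nnn(C)n2)cc1` holds the highest of the three numbers in an in vivo ADME assay on the whole organism for metabolic stability, with Canis familiaris (Canis lupus familiaris) as the target, at a dose of 1 mg/kg by the intravenous route (a lower number here means that the compound disappears faster, a higher number that the compound lasts longer), giving 3.8 h. Compound 1 `Cc1noc(-c2c(F)cccc2-c2ccc([C@@H](C)Nc3nccc(Cl)c3NC(=O)CC#N)cc2)n1` gives 2.1 h in this assay, a gap within the scatter, while compound 3 `COC(=O)c1ccc(Cl)cc1-c1ccc([C@@H](C)Nc2nccc(Cl)c2NC(=O)CC#N)cc1` gives 0.9 h, a gap beyond it. Compound 4 `Cc1nc(-c2c(F)cccc2-c2ccc([C@@H](C)Nc3nccc(Cl)c3NC(=O)CC#N)cc2)no1` differs from compound 2 by 5-methyl-1,2,4-oxadiazol-3-yl in place of 2-methyl-2H-tetrazol-5-yl on an aromatic carbon. Going by the values given here, the one measured step bearing on this is a 1.8-fold higher number from compound 1 to compound 2 (0.26 log units; within the scatter), which exchanged one five-membered heteroaryl for another on an aromatic carbon and stayed within the scatter. Returning to an oxadiazole is therefore expected to give a 1.5-fold lower number from compound 2 to compound 4 (0.16 log units; within the scatter), a step not beyond the scatter in either direction. Compound 4 is estimated at 2.6 h in this assay, with a range of 1.3 h to 5.2 h.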

Compound 4, half-life: 2 h
The estimate for compound 4 lay 1.3-fold (0.11 log units) above the measured number; the measured number falls inside the stated range.
By their numbers in this assay, from the lowest: compound 3; then compounds 4, 1 and 2 (each within the scatter of the next).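

In this assay, the step at this place, ortho to a fluoro group, reads a 1.9-fold lower number from compound 2 to compound 4 (0.28 log units; within the scatter), and the exchange between the two oxadiazole isomers reads a 1.1-fold lower number from compound 1 to compound 4 (0.02 log units; within the scatter). With these steps, 2-methyl-2H-tetrazol-5-yl, 3-methyl-1,2,4-oxadiazol-5-yl and 5-methyl-1,2,4-oxadiazol-3-yl are not separated from one another by this read-out, and the orientation of the oxadiazole shows no step beyond the scatter. No evidence on the cause is available here. From the compounds shown here alone, whether a carboxylic acid or an amine at this place, or a longer chain in place of the methyl on these rings, would step beyond the scatter remains open.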